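A few compounds are considered here, and "the series" means these few. Any claim that something is new, unique, unknown or untested is made for them only; others in the source may bear on it.

Measured in a functional assay on L1210 cells (Mus musculus) for antiproliferative activity, read by cell counting, with a stated time of 48 h; a lower number here means a stronger inhibitor, a higher number a weaker inhibitor:
- compound 1 `C#C[C@@]1(O)[C@@H](CO)O[C@@H](n2cc(Br)c3c(N)ncnc32)[C@@H]1O`: 28 nM
- compound 2 `C#C[C@@]1(O)[C@@H](CO)O[C@@H](n2cc(-c3ccco3)c3c(N)ncnc32)[C@@H]1O`: 30000 nM

For the measured compounds named here, compound 2 holds the higher of the two numbers, and compound 1 is its only neighbour. Next comes compound 3 `C#Cc1cn([C@@H]2O[C@H](CO)[C@](O)(C#C)[C@H]2O)c2ncnc(N)c12`, with this change: ethynyl in place of furan-2-yl on an aromatic carbon. In words, this is ethynyl in place of furan-2-yl on an aromatic carbon, at the same site that separates compound 1 from compound 2.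

Going by the values given here, one measured step bears on this change: a 1100-fold higher number from compound 1 to compound 2 (3.03 log units; beyond the scatter), large and beyond the scatter, with furan-2-yl in place of bromo on an aromatic carbon. Ethynyl, like bromo, brings no ring, so in this assay the furan-2-yl loss is expected to be largely reversed. Among the compounds with values here, no ethynyl compound has been measured at this site, so the recovery may be only partial, and the central expectation stays higher than the number for compound 1, which gives 28 nM.

The expected step is large and towards a lower number: a 200-fold lower number from compound 2 to compound 3 (2.30 log units; beyond the scatter). For compound 3 the estimated value is 150 nM, with an expected range from 20 nM to 1500 nM.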

Compound 3, half-maximal inhibitory concentration: 159000 nM
The estimate for compound 3 lay 1100-fold (3.03 log units) below the measured number; the measured number lies above the stated range.
By their numbers in this assay, from the lowest: compound 1; then compound 2; then compound 3.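

In this assay, taking the ring off this aromatic carbon brings no recovery: the step is a 5.3-fold higher number from compound 2 to compound 3 (0.72 log units; beyond the scatter), so ethynyl, which has no ring, sits further from bromo than furan-2-yl does. Set against bromo directly, ethynyl gives a 5700-fold higher number from compound 1 to compound 3 (3.75 log units; beyond the scatter), which shows that the large loss at this position does not need an aromatic ring in the group, and that the heavy-atom count does not order the numbers, since ethynyl with 2 heavy atoms gives a higher number than furan-2-yl with 5. Nothing measured alongside these numbers accounts for this order, in which bromo alone of the three groups gives a low number.

Still open, from the compounds shown here alone, is whether the low number is particular to bromo or is shared by chloro or iodo on the same carbon. For the compounds shown here, it is also open where a nitrile or an amine at this site would fall relative to bromo and the other two groups, and whether the same order would hold on a core other than the one shared by these compounds.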